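Working notes: chloro for methoxy in a cytotoxicity series

The source may report more compounds than this note shows. Statements on the series, on what has been measured and on what is new or still open speak of the compounds shown alone.

Compound 2 `COc1ccc(CNC(=O)CSc2nc3ccc(NC(C)=O)cc3s2)cc1`, compound 3 `COc1ccc(CNC(=O)CSc2nc3ccc(NC(=O)c4ccccc4)cc3s2)cc1` and compound 1 `O=C(CSc1nc2ccc(NC(=O)c3ccccc3)cc2s1)NCc1ccc(Cl)cc1` have been measured in a functional assay on MCF7 cells (Homo sapiens) for cytotoxicity, read by MTT assay, with a stated time of 48 h; on this read-out higher numbers stand for weaker inhibition and lower numbers for stronger inhibition. Compound 2 gives 20500 nM, compound 3 gives 21200 nM and compound 1 gives 33700 nM. Compound 2 and compound 3 differ only at the carbonyl carbon, (methyl in place of phenyl on a carbonyl carbon), and the measured step between them is a 1.0-fold higher number from compound 2 to compound 3 (0.01 log units; within the scatter). Compound 3 and compound 1 differ by chloro in place of methoxy on an aromatic carbon, and that step is a 1.6-fold higher number from compound 3 to compound 1 (0.20 log units; within the scatter). Compound 4 `CC(=O)Nc1ccc2nc(SCC(=O)NCc3ccc(Cl)cc3)sc2c1` is not yet measured; it carries the core of compound 2 with the change (chloro in place of methoxy on an aromatic carbon), which is the same change as from compound 3 to compound 1, the group sitting at the same place in both pairs. Within the data shown here, the expected step is a 1.3-fold higher number from compound 2 to compound 4 (0.12 log units; within the scatter), which rests on a 1.6-fold higher number from compound 3 to compound 1 (0.20 log units; within the scatter) and on the closeness of compound 2 and compound 3 in this assay, since no other pair bears on this change. Compound 4 is accordingly expected near 27000 nM, within a range from 13000 nM to 55000 nM.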

Compound 4, half-maximal inhibitory concentration: 10200 nM
Compound 4: the middle estimate sits 2.6-fold (0.42 log units) above what was measured; measured number outside the range, below it.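

In this assay, among these compounds, chloro in place of methoxy on the core of compound 2 gives a 2.0-fold lower number from compound 2 to compound 4 (0.30 log units; within the scatter), and this step does not match the one for the same change on the core of compound 3: the same change on two cores in this assay, a 1.6-fold higher number (0.20 log units; within the scatter) from compound 3 to compound 1 and a 2.0-fold lower number (0.30 log units; within the scatter) from compound 2 to compound 4, 3.2-fold (0.50 log units) apart, beyond the scatter of two such steps Methyl in place of phenyl on a carbonyl carbon gives a 3.3-fold lower number from compound 1 to compound 4 (0.52 log units; beyond the scatter), and this step likewise depends on the group at the other place: the same change on two cores in this assay, a 1.0-fold higher number (0.01 log units; within the scatter) from compound 2 to compound 3 and a 3.3-fold higher number (0.52 log units; beyond the scatter) from compound 4 to compound 1, 3.2-fold (0.50 log units) apart, beyond the scatter of two such steps The four compounds therefore show that neither change carries as a fixed step from one core to the other, although each chloro step taken alone lies within the scatter, and they do not show a cause or how the change would behave on any further core.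

Open, going by these compounds, is how an amine or a carboxylic acid in place of chloro or methoxy on that aromatic carbon would read on either core. Also open, on these data alone, is whether a longer chain in place of methyl on the carbonyl carbon would read like compound 4 or like compound 1.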